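The source may report more compounds than this note shows. Statements on the series, on what has been measured and on what is new or still open speak of the compounds shown alone.

Measured in an ADME assay on the whole organism (plasma, Mus musculus, strain CD1), read by LC-MS, with a stated time of 24 h; on this read-out lower numbers stand for a smaller free fraction and higher numbers for a larger free fraction:
- compound 1 `O=C(O)Cn1nc(Cc2nc3cc(F)c(OCC4CC4)cc3[nH]2)c2ccccc2c1=O` gives 0.026
- compound 2 `O=C(O)Cn1nc(Cn2cc3cc(OCC4CC4)c(Cl)cc3n2)c2ccccc2c1=O` gives 0.01
- compound 3 `O=C(O)Cc1nn(Cc2cn3cc(OCC4CC4)c(Cl)cc3n2)c2ccccc2c1=O` gives 0.045

Compound 3 shares the top of this small set with compound 1, the two lying within the scatter of each other, while compound 2 lies beneath compound 3 by more than the scatter. Compound 4 `CCC(C(=O)O)c1nn(Cc2cn3cc(OCC4CC4)c(Cl)cc3n2)c2ccccc2c1=O` differs from compound 3 by one change (ethyl in place of hydrogen on a saturated chain carbon bound to an aromatic carbon and a carbonyl carbon): ethyl in place of hydrogen on a saturated chain carbon bound to an aromatic carbon and a carbonyl carbon. Within the data shown here, no measured pair shows this change, so only a modest shift toward a smaller free fraction is expected in this assay here. The expected step is a 1.8-fold lower number from compound 3 to compound 4 (0.26 log units; within the scatter) and stays within the scatter. For compound 4 the estimate is 0.025 with an expected range from 0.012 to 0.05 in this measurement.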

Compound 4, unbound fraction: 0.013
Compound 4: middle estimate off by 1.9-fold (0.28 log units), on the high side; low and high end bracket the measured number.
By their numbers in this assay, from the lowest: compounds 2, 4, 1 and 3 (each within the scatter of the next, the first and the last beyond it).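

Ethyl in place of hydrogen on this saturated chain carbon, the change from carboxymethyl to 1-carboxypropyl, gives a 3.5-fold lower number from compound 3 to compound 4 (0.54 log units; beyond the scatter) in this assay and so lies beyond the scatter. Among these compounds, the earlier compounds offered no step in one place, so this is the first sign that this carbon bears on the free fraction. No measured evidence here accounts for the shift. The compounds shown leave open whether methyl or a longer chain on this carbon would move the number as far, and whether ethyl would do the same on the other cores.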